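Ethyl for methoxy on the pendant ring of compound 3

This account rests on a few compounds, and the source may have more. Where it says the series, first, only, none or still open, it means among the compounds named here.

Measured compounds:
compound 1 `Cc1ccc(S(=O)(=O)Nc2ccc(-c3ccccc3N3CCCC3)nn2)cc1` — 1.7 nM
compound 2 `Cc1ccc(S(=O)(=O)Nc2ccc(-c3ccccc3N3CCCCC3)nn2)cc1` — 2.4 nM
compound 3 `COc1ccccc1-c1ccc(NS(=O)(=O)c2ccc(C)cc2)nn1` — 36.5 nM

In an assay on mitochondria from liver for inhibition of kynurenine 3-monooxygenase (Mus musculus), read by LC-MS, with stated times of 5 min and 30 min (a lower number here means a stronger inhibitor, a higher number a weaker inhibitor), compound 3 gives 36.5 nM, the highest of the three numbers. The gap to the two amine-bearing compounds is wide: a 21-fold higher number from compound 1 to compound 3 (1.33 log units; beyond the scatter) and a 15-fold higher number from compound 2 to compound 3 (1.18 log units; beyond the scatter). Between compounds 1 and 2 the difference is small: a 1.4-fold higher number from compound 1 to compound 2 (0.15 log units; within the scatter).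

Compound 4 `CCc1ccccc1-c1ccc(NS(=O)(=O)c2ccc(C)cc2)nn1` is the next compound. It differs from compound 3 in one place: ethyl in place of methoxy on an aromatic carbon.

For the measured compounds named here, no measured step matches this change. The two steps that end at compound 3 both replace a ring-bearing amine with methoxy, and both are large. The change to compound 4 replaces methoxy with a group of the same heavy-atom count that carries no ring and no acceptor, so it sits between the two kinds of group already seen, and the measured steps give no direct guide to its direction. Compound 4 is therefore expected to land near compound 3, with a 1.5-fold lower number from compound 3 to compound 4 (0.16 log units; within the scatter) as the estimated step, and the expected result for compound 4 is 25 nM, within a range of 8 nM to 80 nM.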

Compound 4, half-maximal inhibitory concentration: 29.2 nM
Compound 4: middle estimate off by 1.2-fold (0.07 log units), on the low side; low and high end bracket the measured number.
By their numbers in this assay, from the lowest: compounds 1 and 2 (each within the scatter of the next); then compounds 4 and 3 (each within the scatter of the next).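

In this assay the methoxy on this aromatic carbon, ortho to a large group, gives way to ethyl with the same count of heavy atoms and without the hydrogen-bond acceptor, and the step is a 1.3-fold lower number from compound 3 to compound 4 (0.10 log units; within the scatter) so the loss of that acceptor does not separate these two compounds. The wide gap to the amines is also not confined to methoxy, as ethyl in their place gives both a 12-fold higher number from compound 2 to compound 4 (1.09 log units; beyond the scatter) and a 17-fold higher number from compound 1 to compound 4 (1.23 log units; beyond the scatter) and each of these steps is large. Nothing measured here speaks to the reason for these numbers.

The compounds shown leave open whether the low numbers of compound 1 and compound 2 go with the nitrogen of their amines, with their rings or with the two together. Cyclopentyl, a ring without nitrogen, and diethylamino, an amine without a ring, would pull these apart on this aromatic carbon, while a longer chain such as propyl would extend the open-chain series beyond ethyl.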